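The compounds below may be only part of what the source reports. "The series", "measured", "known", "first", "only" and "open" are said of these compounds alone.

Measured in a functional assay on MCF7 cells (Homo sapiens) for antiproliferative activity, read by MTT assay, with a stated time of 24 h; a lower number here means a stronger inhibitor, a higher number a weaker inhibitor:
- compound 1 `CCn1c(C(=O)N[C@@H](C)CO)ccc1C(CC)(CC)c1ccc(OCS(=O)(=O)c2ccccc2)c(C)c1`: 10800 nM
- compound 2 `CCn1c(C(=O)NC2(CO)CC2)ccc1C(CC)(CC)c1ccc(OCS(=O)(=O)c2ccccc2)c(C)c1`: 28800 nM
- compound 3 `CCn1c(C(=O)N[C@H](CO)C(C)C)ccc1C(CC)(CC)c1ccc(OCS(=O)(=O)c2ccccc2)c(C)c1`: 25500 nM

Compound 1 gives the lowest number of the three. Compound 3 cannot be told apart from compound 2, as a 1.1-fold lower number from compound 2 to compound 3 (0.05 log units; within the scatter) shows, and it stands clear of compound 1. The next analogue, compound 4 `CCn1c(C(=O)N[C@H](CO)CCO)ccc1C(CC)(CC)c1ccc(OCS(=O)(=O)c2ccccc2)c(C)c1`, carries 2-hydroxyethyl in place of isopropyl on a saturated chain carbon bound to an amide-type nitrogen and a saturated chain carbon.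

The step bearing most directly on this change is a 2.4-fold higher number from compound 1 to compound 3 (0.37 log units; beyond the scatter), where methyl gives way to isopropyl at that same place. A second step, a 2.7-fold higher number from compound 1 to compound 2 (0.43 log units; beyond the scatter), is of similar size. Neither step tests a 2-hydroxyethyl group, so the direction remains uncertain. With that caveat, a modest step towards a lower number is expected in this assay. The estimated step is a 2.1-fold lower number from compound 3 to compound 4 (0.33 log units; beyond the scatter). Compound 4 is estimated at 12000 nM, with an expected range of 5500 nM to 28000 nM.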

Compound 4, half-maximal inhibitory concentration: 28500 nM
Compound 4: middle estimate off by 2.4-fold (0.38 log units), on the low side, and the stated range ends below it.
By their numbers in this assay, from the lowest: compound 1; then compounds 3, 4 and 2 (each within the scatter of the next).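

In this assay 2-hydroxyethyl in place of isopropyl on this saturated chain carbon makes no difference that can be read (a 1.1-fold higher number from compound 3 to compound 4 (0.05 log units; within the scatter)), so a group with one hydrogen-bond donor and one acceptor reads here like a group with neither. The same holds against the 1-(hydroxymethyl)cyclopropyl group (a 1.0-fold lower number from compound 2 to compound 4 (0.00 log units; within the scatter)), whereas the compound with methyl at this place stands clear (a 2.6-fold higher number from compound 1 to compound 4 (0.42 log units; beyond the scatter)), leaving compound 1 alone apart from the other three. Nothing measured here explains why those three read alike.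

The compounds shown leave open whether an ethyl group at this place would read with compound 1 or with compound 3. They also leave open whether an amine or a carboxylic acid in place of the hydroxyl of the 2-hydroxyethyl group would read with compound 4.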